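The source may report more compounds than this note shows. Statements on the series, on what has been measured and on what is new or still open speak of the compounds shown alone.

Compound 1 `COc1ccc(C2CC(Nc3nc4ccc([N+](=O)[O-])cc4s3)=NN2C(C)=O)cc1` was tested in a functional assay on the whole organism (Hindlimb, strain albino) with Mus musculus as the target, in the maximal electroshock model, with a stated time of 0.5 h (on this read-out higher numbers stand for an effect only at larger amounts of compound and lower numbers for an effect already at smaller amounts), where compound 1 gives 145 umol/kg. Its companion compound 2 `COc1ccc(C2CC(Nc3nc4ccc(Cl)cc4s3)=NN2C(C)=O)cc1` carries a chloro in place of the nitro on an aromatic carbon, and in this assay compound 2 gives 93.3 umol/kg. That step is a 1.6-fold lower number from compound 1 to compound 2 (0.19 log units; within the scatter), so the two compounds cannot be told apart on this read-out; compound 1 simply holds the higher of the two numbers. Among the measured compounds shown here, compound 3 `CC(=O)N1N=C(Nc2nc3ccc([N+](=O)[O-])cc3s2)CC1OC1=CC=C1` changes a different part of the molecule: a group of 5 heavy atoms (4 carbon, 1 oxygen; one four-membered non-aromatic ring of carbon only) in place of a group of 8 heavy atoms (7 carbon, 1 oxygen; one six-membered aromatic ring of carbon only), on a saturated ring carbon The only measured step, from compound 1 to compound 2, swaps a group on an aromatic carbon and says nothing about the saturated ring carbon that is changed here, so no measured step bears directly on this change. With no guidance from the measured pair, the expectation for compound 3 is a step of a 1.1-fold higher number from compound 1 to compound 3 (0.04 log units; within the scatter), that is, nothing beyond the scatter, but with a wide margin. Compound 3 is therefore estimated to give 160 umol/kg in this assay, expected within a range from 60 umol/kg to 450 umol/kg.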

Compound 3, dose for half-maximal effect: 274 umol/kg
Compound 3: middle estimate off by 1.7-fold (0.23 log units), on the low side; low and high end bracket the measured number.
By their numbers in this assay, from the lowest: compounds 2, 1 and 3 (each within the scatter of the next, the first and the last beyond it).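

On the saturated ring carbon next to the ring nitrogen, replacing the 4-methoxyphenyl with a smaller group built on a four-membered non-aromatic ring of carbon only gives, in this assay, a 1.9-fold higher number from compound 1 to compound 3 (0.28 log units; within the scatter). Among the compounds shown here, the earlier pair varied only a group on an aromatic carbon, so this is the first sign that this saturated ring carbon can lose its six-membered aromatic ring without a change beyond the scatter, leaving compound 1 and compound 3 indistinguishable on this read-out. No accompanying measurement helps explain this result.

The compounds shown place the new group only alongside the nitro, so it remains open how it would read with the chloro carried by compound 2. As far as these compounds go, it is also open whether an amine, a carboxylic acid or a longer chain on the same saturated ring carbon would stay within the scatter of compound 1, or whether the read-out would shift clearly at this position.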